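The compounds below may be only part of what the source reports. "The series", "measured", "known", "first", "only" and "open" are said of these compounds alone.

In a functional assay on A-375 cells (Homo sapiens) for antiproliferative activity, read by MTT assay, with a stated time of 24 h (on this read-out higher numbers stand for weaker inhibition and lower numbers for stronger inhibition), compound 1 `COc1cc(OC)c(-c2coc3cc(OCc4ccc(F)cc4)ccc3c2=O)cc1OC` gives 1720 nM and compound 2 `COc1cc(OC)c(-c2coc3cc(OCc4ccccc4C)ccc3c2=O)cc1OC` gives 1360 nM. The step between them, a 1.3-fold lower number from compound 1 to compound 2 (0.10 log units; within the scatter), gives no order to these two values.

Compound 3 `COc1cc(OC)c(-c2coc3cc(OCc4ccc([N+](=O)[O-])cc4)ccc3c2=O)cc1OC` has no number, only a limit, > 10000 nM. It therefore stands as a limit on the numbers shown, beyond the scatter from both other compounds.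

The next change leads to compound 4 `COc1cc(OC)c(-c2coc3cc(OCc4ccccc4Cl)ccc3c2=O)cc1OC`: 2-chlorophenyl in place of 4-nitrophenyl on a saturated chain carbon bound to an oxygen on an aromatic ring, with 2-chlorophenyl in place of 4-nitrophenyl on a saturated chain carbon bound to an oxygen on an aromatic ring.

For the measured compounds named here, two measured steps bear on it, both entering the 4-nitrophenyl that compound 4 gives up: an at least 5.8-fold higher number from compound 1 to compound 3 (0.76 log units; beyond the scatter) and an at least 7.3-fold higher number from compound 2 to compound 3 (0.86 log units; beyond the scatter). The second is the closer guide, since the 2-methylphenyl of compound 2 is the nearest group to 2-chlorophenyl in the series. Reversing that step, a move to a lower number in this assay is expected, of similar size and beyond the scatter. The expected step is an at least 6.6-fold lower number from compound 3 to compound 4 (0.82 log units; beyond the scatter).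

Compound 4 is estimated at 1500 nM, with an expected range of 600 nM to 4000 nM.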

Compound 4, half-maximal inhibitory concentration: 2020 nM
The estimate for compound 4 lay 1.3-fold (0.13 log units) below the measured number; measured number inside the range.
By their numbers in this assay, from the lowest: compounds 2, 1 and 4 (each within the scatter of the next). At a limit, above all of these: compound 3.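

In this assay, 2-chlorophenyl in place of 4-nitrophenyl on a saturated chain carbon bound to an oxygen on an aromatic ring gives an at least 4.9-fold lower number from compound 3 to compound 4 (0.69 log units; beyond the scatter), so a change at this place alone moves the read-out beyond the scatter in the direction opposite to the entry of 4-nitrophenyl. Chloro in place of methyl on an aromatic carbon gives a 1.5-fold higher number from compound 2 to compound 4 (0.17 log units; within the scatter), and the change from 4-fluorophenyl to 2-chlorophenyl gives a 1.2-fold higher number from compound 1 to compound 4 (0.07 log units; within the scatter), so three different groups here cannot be told apart and only 4-nitrophenyl stands off from them. The entry for compound 3 is a limit, not a number: the limit of > 10000 nM in this assay, at which 1 of the 4 values shown sits.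

On these data alone, whether the nitro group itself or its place on the ring sets compound 3 apart stays open, and 2-nitrophenyl or 4-chlorophenyl would separate the two. Also open, as far as these compounds go, is how an amine or a carboxylic acid on this phenyl ring would read.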